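This account rests on a few compounds, and the source may have more. Where it says the series, first, only, none or still open, it means among the compounds named here.

Compound 3 `N#CC1=C(N)Oc2c(N)cc3nc4ccccc4nc3c2C12C(=O)N(Cc1cnnn1-c1cc(Cl)ccc1Cl)c1ccccc12` is known only as a limit in a functional assay on HCT-116 cells (Homo sapiens) for antiproliferative activity, read by MTT assay, with a stated time of 48 h (a lower number here means a stronger inhibitor, a higher number a weaker inhibitor), where compound 3 gives > 50000 nM. Compound 1 `CCc1cccc(C)c1-n1nncc1CN1C(=O)C2(C(C#N)=C(N)Oc3c(N)cc4nc5ccccc5nc4c32)c2ccccc21` likewise reaches a limit, giving > 50000 nM in this assay. Compound 2 `CCc1cccc(CC)c1-n1nncc1CN1C(=O)C2(C(C#N)=C(N)Oc3c(N)cc4nc5ccccc5nc4c32)c2ccccc21` gives 37600 nM in this assay. Compound 4 `Cc1cc(C)c(-n2nncc2CN2C(=O)C3(C(C#N)=C(N)Oc4c(N)cc5nc6ccccc6nc5c43)c3ccccc32)c(C)c1` carries the change (2,4,6-trimethylphenyl in place of 2,5-dichlorophenyl on an aromatic nitrogen). Two measured steps alter the same aryl group on the aromatic nitrogen: a step that the two limits leave unreadable from compound 1 to compound 3 and an at least 1.3-fold higher number from compound 2 to compound 3 (0.12 log units; that floor lies within the scatter). Read in the reverse direction, the second hints at a small lowering, while the limit of > 50000 nM in this assay, at which 2 of the 3 values shown sit, leaves little room to read more from compound 1. Compound 4 is therefore expected to stay near the limit, a step of an at least 1.1-fold lower number from compound 3 to compound 4 (0.04 log units; that floor lies within the scatter), with an estimate of 45000 nM and a range from 20000 nM to 100000 nM.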

Compound 4, half-maximal inhibitory concentration: > 50000 nM
Compound 4: a limit, no number; the forecaster's own chance of this, stated with the estimate: 55%; middle value at least 1.1-fold (0.04 log units) away from the limit.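

In this assay, compound 4 ends at a limit of the assay, so its 2,4,6-trimethylphenyl group joins the two other aryl groups on this aromatic nitrogen that give no number. Among the compounds shown here, the steps to compound 1 and compound 3 cannot be read, and the only readable step is an at least 1.3-fold higher number from compound 2 to compound 4 (0.12 log units; that floor lies within the scatter). Compound 2 therefore remains the only compound with a number, and the series offers little to compare: the limit of > 50000 nM in this assay, at which 3 of the 4 values shown sit.

The compounds shown leave open how a phenyl ring bearing an amine or a carboxylic acid would read in this assay. They also leave open whether a longer chain, such as propyl in place of the ethyl groups of compound 2, would give a number.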